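The compounds below may be only part of what the source reports. "The series", "measured", "known", "first", "only" and "open" are said of these compounds alone.

Three compounds built on one shared fused core were tested in a functional assay on PC-3 cells (Homo sapiens) for cytotoxicity, read by sulforhodamine B assay, with a stated time of 48 h; a higher number here means a weaker inhibitor of growth, a lower number a stronger inhibitor of growth. Compound 1 `ClCc1ccc(Cn2cnc3c(Cl)ncnc32)cc1` gives 72400 nM, the highest of the three numbers. Compound 2 `ClCc1cccc(Cn2cnc3c(Cl)ncnc32)c1` gives 18200 nM, lower by more than the usual scatter, while compound 3 `ClCc1ccc(Cn2cnc3nc(Cl)nc(Cl)c32)cc1` gives 37200 nM, which lies within the scatter of compound 1. The next compound, compound 4 `ClCc1ccc(Cn2cnc3c(Cl)nc(Cl)nc32)cc1`, has not yet been measured; it differs from compound 1 by chloro in place of hydrogen on an aromatic carbon, the new chloro standing between two ring nitrogen atoms of the six-membered ring in the fused system. Compound 3 also carries a second chloro on the core, and its value of 37200 nM sits close to compound 1, so only a small move downward, if any beyond the scatter, is expected here. Compound 4 is estimated at 40000 nM, a step of a 1.8-fold lower number from compound 1 to compound 4 (0.26 log units; within the scatter), with an expected range from 15000 nM to 110000 nM.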

Compound 4, concentration for total growth inhibition: 7240 nM
Estimate against measurement, compound 4: 5.5-fold (0.74 log units) above, and the stated range ends above it.
By their numbers in this assay, from the lowest: compound 4; then compound 2; then compounds 3 and 1 (each within the scatter of the next).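

In this assay, going by these compounds alone, chloro in place of hydrogen on the aromatic carbon between two ring nitrogen atoms gives a 10-fold lower number from compound 1 to compound 4 (1.00 log units; beyond the scatter) and so provides the first comparison here of compounds differing in one place. It shows that this single change at this position can move the number beyond the usual scatter. No measurement shown here explains the size of this step. Going by these compounds, whether an amine or a methoxy group on the same carbon would give a similar step remains open, as does whether adding chloro there would do the same in compound 2.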